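This account rests on a few compounds, and the source may have more. Where it says the series, first, only, none or still open, it means among the compounds named here.

In a functional assay on HepG2 cells (Homo sapiens) for antiproliferative activity, read by colorimetric assay and MTT assay, with a stated time of 48 h (on this read-out higher numbers stand for weaker inhibition and lower numbers for stronger inhibition), compound 1 `O=C(NS(=O)(=O)c1ccccc1)c1cccnc1` gives 10400 nM and compound 2 `O=C(NS(=O)(=O)c1ccc(F)cc1)c1ccncc1` gives 12400 nM while compound 3 `O=C(NS(=O)(=O)c1ccccc1)c1ccccn1` gives 9900 nM so all three lie within the scatter of one another. Compound 3 therefore stands level with the other two. Compound 4 `O=C(NS(=O)(=O)c1ccc(Br)cc1)c1ccccn1` follows from compound 3 through bromo in place of hydrogen on an aromatic carbon and has no number yet. Among the measured compounds shown here, only one measured step joins compounds that differ in one place: a 1.1-fold lower number from compound 1 to compound 3 (0.02 log units; within the scatter) is that step, and it concerns the group on the carbonyl carbon, so it does not speak directly to bromo in place of hydrogen. Compound 2 carries fluoro on its ring of carbon only but also differs from compound 3 in a second place, so compound 2 with its 12400 nM offers only a loose hint. For the measured compounds named here, no bromo compound has been measured, so the range is kept wide, and no step beyond the scatter is expected in this assay on this evidence. The expected step is a 1.2-fold lower number from compound 3 to compound 4 (0.07 log units; within the scatter) and it is expected to stay within the scatter. For compound 4 the estimate is 8500 nM with an expected range from 3800 nM to 17000 nM in this read-out.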

Compound 4, half-maximal inhibitory concentration: 5000 nM
For compound 4 the middle estimate is 1.7-fold (0.23 log units) above the measured one; the measured number falls inside the stated range.
By their numbers in this assay, from the lowest: compounds 4, 3, 1 and 2 (each within the scatter of the next, the first and the last beyond it).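

Among the compounds shown here, this is the first step in the piece that changes the ring of carbon only while leaving the rest of the structure untouched, as the earlier measured step concerned only the group on the carbonyl carbon. In this assay, bromo in place of hydrogen on an aromatic carbon, para to a large group, gives a 2.0-fold lower number from compound 3 to compound 4 (0.30 log units; within the scatter), so adding this single heavy atom at this position leaves the number within the scatter of compound 3. Nothing given here accounts for the size of this step.

With only bromo shown at this position, it remains open whether an amine, a carboxylic acid or a methoxy group in the same place would give a step beyond the scatter. From the compounds shown here alone, it also remains open whether bromo would give a similar step on the core of compound 1, which carries pyridin-3-yl on the carbonyl carbon.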